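The compounds below may be only part of what the source reports. "The series", "measured", "known", "first", "only" and "open" are said of these compounds alone.

Measured compounds:
- compound 1 `CCCOc1cc(C(F)(F)F)ccc1CNC(=O)C(C)c1ccc(NS(C)(=O)=O)c(F)c1` — 2 nM
- compound 2 `CC(C(=O)NCc1ccc(C(F)(F)F)cc1SCCCO)c1ccc(NS(C)(=O)=O)c(F)c1` — "not active" (no number reported)
- compound 3 `CC(C(=O)NCc1ccc(C(F)(F)F)cc1SC1CCCC1)c1ccc(NS(C)(=O)=O)c(F)c1` — 0.3 nM

In an assay on CHO cells for antagonist activity at transient receptor potential cation channel subfamily V member 1 (Homo sapiens), read by FLIPR (a higher number here means a weaker inhibitor, a lower number a stronger inhibitor), compound 3 gives 0.3 nM, the lowest of the two numbers in hand. For the measured compounds named here, the only single-point step available is a 6.7-fold lower number from compound 1 to compound 3 (0.82 log units; beyond the scatter), a modest step beyond the scatter. In this assay compound 2 gives "not active" (no number reported), with no number reported. Compound 2 differs from compounds 1 and 3 in this same substituent.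

Compound 4 `COc1cc(OC)cc(-c2cc(C(F)(F)F)ccc2CNC(=O)C(C)c2ccc(NS(C)(=O)=O)c(F)c2)c1` is the next variant. Change from compound 3: 3,5-dimethoxyphenyl in place of cyclopentylsulfanyl on an aromatic carbon

Going by the values given here, no measured step covers an aromatic group entering here; the step from propoxy to cyclopentylsulfanyl shows that the substituent matters and that the series spans from an inactive entry to a sub-nanomolar one, so the uncertainty is wide. A 3,5-dimethoxyphenyl group is larger than cyclopentylsulfanyl and unrelated to either measured substituent, so the expectation leans toward a somewhat higher number than compound 3, roughly back toward compound 1, without a firm basis for direction. The expected step is a 10-fold higher number from compound 3 to compound 4 (1.00 log units; beyond the scatter). Compound 4 is estimated at 3 nM in this assay, with a range of 0.4 nM to 25 nM.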

Compound 4, inhibition constant: 5.8 nM
The estimate for compound 4 lay 1.9-fold (0.29 log units) below the measured number, within the range that was stated.
By their numbers in this assay, from the lowest: compound 3; then compound 1; then compound 4.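

In this assay, for the compounds shown here, the aromatic carbon ortho to a large group and meta to a trifluoromethyl group accepts a six-membered aromatic ring of carbon only and still gives a numerical result, so this position is not limited to the propoxy and cyclopentylsulfanyl groups of the compounds with numbers so far. The cost depends on the comparison: 3,5-dimethoxyphenyl in place of cyclopentylsulfanyl gives a 19-fold higher number from compound 3 to compound 4 (1.29 log units; beyond the scatter) as a large step, while 3,5-dimethoxyphenyl in place of propoxy gives a 2.9-fold higher number from compound 1 to compound 4 (0.46 log units; beyond the scatter) as a modest one, and both lie beyond the scatter. Nothing in the data accounts for this ranking of the three substituents.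

The compounds shown do not separate the contribution of the aromatic ring from that of its two methoxy groups, so an unsubstituted phenyl group or a single methoxy group on the ring remains an open comparison at this position. Also open, on these data alone, is how a piperidine ring or a carboxylic acid would behave here, and compound 2 still gives no number against which to set any of these groups.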